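Side-chain exchange from compound 2 to compound 3

The compounds below may be only part of what the source reports. "The series", "measured", "known", "first", "only" and "open" are said of these compounds alone.

Measured so far in a functional assay on PC-3 cells (Homo sapiens) for antiproliferative activity, read by MTT assay, with a stated time of 24 h; a lower number here means a stronger inhibitor, a higher number a weaker inhibitor
- compound 1 `CCn1c(C(=O)N[C@H](CO)CCCO)ccc1C(CC)(CC)c1ccc(OCS(=O)(=O)c2ccccc2)c(C)c1` at 6810 nM
- compound 2 `CCn1c(C(=O)N[C@H](C(=O)O)C(C)C)ccc1C(CC)(CC)c1ccc(OCS(=O)(=O)c2ccccc2)c(C)c1` at 3650 nM

Going by the values given here, compound 2 stands within the scatter of compound 1, the only other measured compound, so the two cannot be ranked. Among the compounds with values here, the one measured step (a 1.9-fold lower number from compound 1 to compound 2 (0.27 log units; within the scatter)) is an exchange of one group on an amide-type nitrogen for another of equal heavy-atom count.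

Compound 3 `CCn1c(C(=O)N[C@@H](CC(=O)O)C(=O)O)ccc1C(CC)(CC)c1ccc(OCS(=O)(=O)c2ccccc2)c(C)c1` has not yet been measured. It carries carboxymethyl in place of the isopropyl of compound 2, on a saturated chain carbon bound to an amide-type nitrogen and a carbonyl carbon (carboxymethyl in place of isopropyl on a saturated chain carbon bound to an amide-type nitrogen and a carbonyl carbon). This turns 1-carboxy-2-methylpropyl into 1,2-dicarboxyethyl. Within the data shown here, no measured compound carries that group, so the data give no firm direction and the range stays wide.

Among the measured compounds shown here, with only that one small step as a guide, no change beyond the scatter is expected in this assay for this exchange. The expected size is a 1.2-fold higher number from compound 2 to compound 3 (0.09 log units; within the scatter) as an estimate. For compound 3 the estimated value is 4500 nM with an expected range from 1500 nM to 13000 nM in this read-out.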

Compound 3, half-maximal inhibitory concentration: > 50000 nM
Compound 3 ended at the assay's limit (the forecaster's own chance of this, stated with the estimate: 10%); middle value at least 11-fold (1.04 log units) from the limit.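

In this assay, going by these compounds alone, the saturated chain carbon bound to an amide-type nitrogen and a carbonyl carbon is the first place where an exchange moves the read-out beyond the scatter: carboxymethyl in place of isopropyl gives an at least 13-fold higher number from compound 2 to compound 3 (1.13 log units; beyond the scatter). The value of compound 3 is a limit of the assay and not a number: the limit of > 50000 nM in this assay, at which 1 of the 3 values shown sits.
Within the data shown here, the separation holds against the other earlier side chain as well, with an at least 7.3-fold higher number from compound 1 to compound 3 (0.86 log units; beyond the scatter), whereas the only earlier step, a 1.9-fold lower number from compound 1 to compound 2 (0.27 log units; within the scatter), stayed within the scatter.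

The compounds shown leave open whether the step follows the second carboxylic acid itself or the chain that carries it; a methyl ester or a primary amide in its place, or a plain propyl chain at the same carbon, would separate these readings. Also open, going by these compounds, is whether any group at this place, such as an amine or a longer alkyl chain, gives a number lower than that of compound 2 by more than the scatter.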